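The source may hold more compounds than are shown below. What is called first, only, known or untested is meant among the compounds shown, and "the series" means these compounds.

Compound 3 `Clc1ccc(C(c2cncnc2)c2ccccc2Cl)cc1` has only a limit in an ADME assay on L6 cells (Rattus norvegicus) for cytotoxicity, read by resazurin assay, with a stated time of 72 h (a lower number here means a stronger inhibitor, a higher number a weaker inhibitor), > 100000 nM. Compound 4 `Clc1ccc(C(c2cccnc2)c2ccccc2Cl)cc1` differs from it by pyridin-3-yl in place of pyrimidin-5-yl on a saturated chain carbon bound to two aromatic carbons. The nearest guide comes from two compounds that also carry pyridin-3-yl: compound 1 `OC(c1ccc(Cl)cc1)(c1cccnc1)c1ccccc1Cl` gives 61300 nM, and compound 2 `CC(C)CNC(c1ccc(Cl)cc1)(c1cccnc1)c1ccccc1Cl` gives 59200 nM. Among the compounds with values here, the one measured step, a 1.0-fold lower number from compound 1 to compound 2 (0.02 log units; within the scatter), changes a different place and does not measure this exchange. Its size does suggest that the values of pyridin-3-yl compounds may stay close together. A modest step towards a lower number is therefore expected, an at least 1.6-fold lower number from compound 3 to compound 4 (0.22 log units; that floor lies within the scatter). In this assay, compound 4 is estimated at 60000 nM, with an expected range of 28000 nM to 100000 nM.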

Compound 4, half-maximal inhibitory concentration: 62300 nM
For compound 4 the middle estimate is 1.0-fold (0.02 log units) below the measured one; low and high end bracket the measured number.
By their numbers in this assay, from the lowest: compounds 2, 1 and 4 (each within the scatter of the next). At a limit, above all of these: compound 3.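

In this assay, pyridin-3-yl in place of pyrimidin-5-yl gives an at least 1.6-fold lower number from compound 3 to compound 4 (0.20 log units; that floor lies within the scatter), a step that rests on a limit and so has no exact size. With hydrogen in place of isobutylamino or hydroxy on the saturated chain carbon, the values stay level: a 1.1-fold higher number from compound 2 to compound 4 (0.02 log units; within the scatter), and a 1.0-fold higher number from compound 1 to compound 4 (0.01 log units; within the scatter). Compound 3 stands only at a limit of the assay: the limit of > 100000 nM in this assay, at which 1 of the 4 values shown sits.

The compounds shown leave open how the number would answer to a carboxylic acid or a longer chain on the saturated chain carbon. They also leave open the true value of compound 3.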